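A Bulkier Ester Group on the Shared Core

A few compounds are considered here, and "the series" means these few. Any claim that something is new, unique, unknown or untested is made for them only; others in the source may bear on it.

Three compounds have so far been measured in an assay for inhibition of 3-hydroxy-3-methylglutaryl-coenzyme A reductase (Rattus norvegicus); on this read-out lower numbers stand for stronger inhibition and higher numbers for weaker inhibition:

Compound 1 `CC(C)C(=O)O[C@H]1C[C@@H](C)C=C2C=C[C@H](C)[C@H](CC[C@@H]3C[C@@H](O)CC(=O)O3)C21` gives 7.7 nM.
Compound 2 `C[C@H]1C=C2C=C[C@H](C)[C@H](CC[C@@H]3C[C@@H](O)CC(=O)O3)C2[C@@H](OC(=O)C2CC2)C1` gives 38.6 nM.
Compound 3 `C=C(C)CC(=O)O[C@H]1C[C@@H](C)C=C2C=C[C@H](C)[C@H](CC[C@@H]3C[C@@H](O)CC(=O)O3)C21` gives 2.9 nM.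

All three share one core and differ only in the group attached to the carbonyl carbon of an ester. Compound 3 has the lowest number of the three, and both of its steps lie beyond the scatter: a 2.7-fold lower number from compound 1 to compound 3 (0.42 log units; beyond the scatter) and a 13-fold lower number from compound 2 to compound 3 (1.12 log units; beyond the scatter). The remaining step, a 5.0-fold higher number from compound 1 to compound 2 (0.70 log units; beyond the scatter), shows that a small exchange at this same carbonyl carbon can also weaken inhibition.

Compound 4 `CCCC(CC)(CC)C(=O)O[C@H]1C[C@@H](C)C=C2C=C[C@H](C)[C@H](CC[C@@H]3C[C@@H](O)CC(=O)O3)C21` carries the change (1,1-diethylbutyl in place of 2-methylprop-2-en-1-yl on a carbonyl carbon). Going by the values given here, none of the measured steps covers a group of this size; all three concern smaller groups, and they ran in both directions, from modest to large. The measured steps give no ground to expect a further gain over compound 3, but they also show that an open-chain group at this position can sit among the stronger inhibitors.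

The expected step of a 2.1-fold higher number from compound 3 to compound 4 (0.32 log units; beyond the scatter) is therefore a modest weakening. Compound 4 is expected to give about 6 nM in this assay, with a range from 2 nM to 20 nM.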

Compound 4, half-maximal inhibitory concentration: 1.9 nM
The estimate for compound 4 lay 3.2-fold (0.50 log units) above the measured number; the measured number lies below the stated range.
By their numbers in this assay, from the lowest: compounds 4 and 3 (each within the scatter of the next); then compound 1; then compound 2.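

Changing the group on the carbonyl carbon from 4 heavy atoms in 2-methylprop-2-en-1-yl to 8 in 1,1-diethylbutyl costs nothing that can be read in this assay, since a 1.5-fold lower number from compound 3 to compound 4 (0.18 log units; within the scatter) leaves compound 3 and compound 4 indistinguishable. The larger group also holds its advantage over the smaller ones, with a 4.1-fold lower number from compound 1 to compound 4 (0.61 log units; beyond the scatter) when it replaces isopropyl and a 20-fold lower number from compound 2 to compound 4 (1.31 log units; beyond the scatter) when it replaces cyclopropyl, both steps lying beyond the scatter. Among these four compounds, then, 1,1-diethylbutyl sits with the strongest inhibitors rather than paying a penalty for its size, and no upper limit on size has yet appeared at this position.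

Going by these compounds, it remains open whether a still longer chain, or a chain carrying an amine or a carboxylic acid, would keep inhibition at this level. Nothing available here bears on why these groups rank as they do.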